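The source may report more compounds than this note shows. Statements on the series, on what has been measured and on what is new or still open speak of the compounds shown alone.

Compound 1 `CC(C)C/N=c1\c(O)c(O)\c1=N/Cc1ccc(C#N)cc1` is examined in a functional assay for inhibition, with Rattus norvegicus as the target (on this read-out lower numbers stand for stronger inhibition and higher numbers for weaker inhibition), and stands at the higher of the two numbers that have been read: in this assay compound 1 gives 10200 nM. For the measured compounds named here, compound 3 `CC(C)(C)/N=c1\c(O)c(O)\c1=N/Cc1ccc(Cl)cc1` gives 1700 nM in this assay, a clearly lower number, but compound 3 differs from compound 1 in more than one place, so no single step joins the two and only the two values themselves can be compared. Compound 2 `N#Cc1ccc(CNc2c(N)c(=O)c2=O)cc1` reaches only a limit of this assay, > 30000 nM. That limit is the limit of > 30000 nM in this assay, at which 1 of the 3 values shown sits.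

Compound 4 `CCC(C)(C)/N=c1\c(O)c(O)\c1=N/Cc1ccc(C#N)cc1` has not yet been measured. It differs from compound 1 in one place: 1,1-dimethylpropyl in place of isobutyl on a double-bonded nitrogen. Going by the values given here, no measured step exists between compounds differing only there, so the expectation rests on the values of compound 1 and compound 3 alone. The step is expected to be a 2.6-fold lower number from compound 1 to compound 4 (0.41 log units; beyond the scatter) in this assay, toward a lower number, and of modest size. In this assay compound 4 is therefore estimated to give about 4000 nM, within a range from 1200 nM to 13000 nM.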

Compound 4, half-maximal inhibitory concentration: 1100 nM
Estimate against measurement, compound 4: 3.6-fold (0.56 log units) above; the whole stated range lies above it.
By their numbers in this assay, from the lowest: compounds 4 and 3 (each within the scatter of the next); then compound 1. At a limit, above all of these: compound 2.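

In this assay the change to 1,1-dimethylpropyl in place of isobutyl on the double-bonded nitrogen gives a 9.3-fold lower number from compound 1 to compound 4 (0.97 log units; beyond the scatter) and provides the first step shown that isolates this position. The earlier compounds shown here differed from one another in more than one place, whereas here the rest of the structure stays the same, so the change in the number belongs to this group swap alone. Both groups are carbon-only chains with no ring, no hydrogen-bond donors or acceptors and no net charge, so the step arises without any change in those counts.

A single step cannot say how the number would move with a straight pentyl chain or a cyclohexyl ring on this nitrogen. Nothing among the data shown explains why this change gives a step of this size.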